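The source may hold more compounds than are shown below. What is called first, only, known or untested is meant among the compounds shown, and "the series" means these compounds.

Of the compounds shown here, two that share one core have so far been measured in a physicochemical assay for lipophilicity, read by HPLC, in phosphate buffer, measured as chromatographic lipophilicity, at pH 7.4; a higher number here means a more lipophilic compound, a lower number a more polar compound. Compound 1 `COc1ccc2nc(C)cc(OCC(=O)Nc3ccc(Br)c(C)c3)c2c1` gives 5.95 in this assay. Compound 2 `COc1ccc2nc(C)cc(OCC(=O)Nc3ccc(Cl)c(C(F)(F)F)c3)c2c1` gives 6.22 in this assay. These two numbers lie within the usual scatter of each other, so on this evidence neither compound can be placed ahead of the other, and compound 1 simply sits alongside compound 2.

Compound 3 `COc1ccc2nc(C)cc(OCC(=O)Nc3nccs3)c2c1` has not yet been measured. It differs from compound 1 in a single place: 1,3-thiazol-2-yl in place of 4-bromo-3-methylphenyl on an amide-type nitrogen. Going by the values given here, no measured pair shows this change on its own, so its size cannot be read from the data and can only be estimated. With a five-membered aromatic ring with 2 hetero atoms entering where a six-membered aromatic ring of carbon only carrying a bromine leaves, a drop from compound 1 to compound 3 of about a number 1.95 log units lower from compound 1 to compound 3 (beyond the scatter) is expected, well beyond the scatter. Compound 3 is accordingly estimated at 4 in this assay, with a likely range from 3.3 to 4.7.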

Compound 3, distribution coefficient: 3.2
For compound 3 the middle estimate is 0.80 log units above the measured one; the whole stated range lies above it.
By their numbers in this assay, from the lowest: compound 3; then compounds 1 and 2 (each within the scatter of the next).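

Changing the group on the amide-type nitrogen from 4-bromo-3-methylphenyl to 1,3-thiazol-2-yl gives, in this assay, a number 2.75 log units lower from compound 1 to compound 3 (beyond the scatter), so this position can carry a large shift in the reading. No single change here had been seen on its own before this step. The change is not a simple one, since a six-membered aromatic ring of carbon only with its bromine and methyl leaves, a five-membered aromatic ring with 2 hetero atoms enters, and hydrogen-bond acceptors go from 0 to 2, but nothing available shows which of these differences accounts for the step.

Still open, from the compounds shown here alone, is how a plain phenyl ring would read, as it would separate the ring swap from the bromine and methyl. Also open, going by these compounds, is where a pyridine ring or a chain ending in an amine would fall in this assay.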